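Adding methoxy to compound 2: an expected small step

This account rests on a few compounds, and the source may have more. Where it says the series, first, only, none or still open, it means among the compounds named here.

Compound 1 `O=C(CCCCCC(=O)Nc1ccc(O)c(C(=O)Nc2ccccc2)c1)NO` gives 14600 nM
Compound 2 `O=C(CCCCCC(=O)Nc1ccc(O)c(C(=O)Nc2ccc(F)c(Cl)c2)c1)NO` gives 21100 nM
Compound 3 `O=C(CCCCCC(=O)Nc1ccc(O)c(C(=O)Nc2cccc(C(F)(F)F)c2)c1)NO` gives 25700 nM

In a functional assay on A549 cells (Homo sapiens) for antiproliferative activity, read by MTT assay, with a stated time of 48 h (on this read-out lower numbers stand for stronger inhibition and higher numbers for weaker inhibition), compound 2 cannot be told apart from its two neighbours, with a 1.4-fold higher number from compound 1 to compound 2 (0.16 log units; within the scatter) on one side and a 1.2-fold higher number from compound 2 to compound 3 (0.09 log units; within the scatter) on the other, both within the scatter of repeated measurements. The next molecule is compound 4 `COc1cc(O)c(C(=O)Nc2ccc(F)c(Cl)c2)cc1NC(=O)CCCCCC(=O)NO`, which differs from compound 2 by one change: methoxy in place of hydrogen on an aromatic carbon. Put simply, this is methoxy in place of hydrogen on an aromatic carbon.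

The three measured steps give only indirect guidance, since all of them swap substituents on a different ring. Even a 1.8-fold higher number from compound 1 to compound 3 (0.25 log units; within the scatter) stays within the scatter. These compounds therefore show a flat response to changes on that other ring, but they say nothing direct about methoxy on this one. The expectation in this assay is no step beyond the scatter and no favoured direction.

For compound 4 the expected step is a 1.1-fold lower number from compound 2 to compound 4 (0.02 log units; within the scatter) and no larger change is predicted. The estimated value for compound 4 is 20000 nM, with an expected range from 8000 nM to 45000 nM as its limits.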

Compound 4, half-maximal inhibitory concentration: 24100 nM
For compound 4 the middle estimate is 1.2-fold (0.08 log units) below the measured one; the range from low to high includes it.
By their numbers in this assay, from the lowest: compounds 1, 2, 4 and 3 (each within the scatter of the next).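

In this assay, methoxy in place of hydrogen gives a 1.1-fold higher number from compound 2 to compound 4 (0.06 log units; within the scatter), so this change makes no readable difference. The earlier steps shown here all changed the other ring and could only hint at this. This step tests the ring carrying the hydroxy group directly, and shows that a methoxy group can sit on this carbon, meta to that hydroxy group, with the number staying within the scatter.

Going by these compounds, one group at one carbon cannot show how flat this position really is: an amine, a carboxylic acid or a longer chain such as ethoxy could behave differently here, and whether methoxy would do the same alongside the other amide rings of compound 1 and compound 3 remains open. Nothing measured here offers an explanation for the result.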